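Hydroxymethyl to methyl: the step from compound 3

A few compounds are considered here, and "the series" means these few. Any claim that something is new, unique, unknown or untested is made for them only; others in the source may bear on it.

Of the compounds shown here, three have been tested in a functional assay on MDA-MB-231 cells (Homo sapiens) for cytotoxicity, read by MTT assay; on this read-out lower numbers stand for stronger inhibition and higher numbers for weaker inhibition: compound 1 (`CC(=O)O[C@@H]1[C@H]2O[C@@]3(C[C@H](C)[C@H](OC(=O)c4ccccc4)[C@@H]3/C=C(\C)[C@H](OC(C)=O)C[C@@H](OC(C)=O)C1(C)C)[C@@H](OC(C)=O)[C@H]2C`), compound 2 (`CC(=O)O[C@H]1[C@@H](C)/C=C/C(C)(C)[C@H](O)C[C@@H](O)/C(C)=C/[C@H]2[C@@H](OC(=O)c3ccccc3)[C@@H](C)C[C@@]21O`) and compound 3 (`CC(=O)O[C@@H]1C[C@@H](OC(C)=O)C(C)(C)/C=C/[C@H](C)[C@H](OC(C)=O)[C@@]2(O)C[C@H](C)[C@H](OC(=O)c3ccccc3)[C@@H]2/C=C/1CO`). Compound 1 gives > 10000 nM, which is a limit of the assay and not a number. Compound 2 gives > 10000 nM, again a limit. Compound 3 gives > 10000 nM, also a limit. All three therefore sit at one place on the scale, (the limit of > 10000 nM in this assay, at which 3 of the 3 values shown sit), and compound 3 has no exact number of its own.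

The next compound, compound 4 (`CC(=O)O[C@@H]1C[C@@H](OC(C)=O)C(C)(C)/C=C/[C@H](C)[C@H](OC(C)=O)[C@@]2(O)C[C@H](C)[C@H](OC(=O)c3ccccc3)[C@@H]2/C=C/1C`), differs from compound 3 in a single place: hydrogen in place of hydroxy on a saturated chain carbon bound to a double-bonded ring carbon. This puts hydrogen in place of hydroxy on a saturated chain carbon bound to a double-bonded ring carbon, which turns hydroxymethyl to methyl. For the measured compounds named here, no measured pair here shows what this change does. In this assay no step beyond the usual scatter is expected, in either direction, and this expectation rests only on the three limits seen so far. The expected step that the limit leaves unreadable from compound 3 to compound 4 is an estimate only. For compound 4 the estimated value is 15000 nM, with an expected range from 7000 nM to 40000 nM, and the assay may well report only a limit again.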

Compound 4, half-maximal inhibitory concentration: 13400 nM
Estimate against measurement, compound 4: 1.1-fold (0.05 log units) above, and the stated range covers the measured number.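

Compound 4 has an exact number, but compound 3 has only a limit, so no step can be read between them, because of where the values sit: the limit of > 10000 nM in this assay, at which 3 of the 4 values shown sit.

As far as these compounds go, what hydroxymethyl to methyl does in this assay stays open, including its direction, as does how far compound 1, compound 2 and compound 3 lie beyond the limit.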